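The compounds below may be only part of what the source reports. "The series", "measured", "known", "first", "only" and "open" are said of these compounds alone.

Of the compounds shown here, three built on one shared core have been tested in an ADME assay on WI-38 cells (Homo sapiens) for cytotoxicity, read by colorimetric assay and crystal violet staining, with a stated time of 24 h (on this read-out lower numbers stand for stronger inhibition and higher numbers for weaker inhibition), and they differ only in the aromatic ring that sits on the carbon with a double bond to nitrogen. Compound 1 `COc1ccc(/C=N/NC(=O)c2ccc(-c3ccc(Cl)cc3)nc2C)cc1OC` gives 443 ug/mL. Compound 2 `COc1ccc(/C=N/NC(=O)c2ccc(-c3cccc(Cl)c3)nc2C)cc1` gives 500 ug/mL. Compound 3 `COc1cccc(/C=N/NC(=O)c2ccc(-c3ccc(Cl)cc3)nc2C)c1O` gives 500 ug/mL, the same number as compound 2 at the digits shown, and its gap to compound 1 lies within the usual scatter of repeated measurements. All three therefore read as a single level of weak cytotoxicity, and none of the differences between them counts as a real step.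

Compound 4 `COc1ccc(/C=N/NC(=O)c2ccc(-c3ccc(Cl)cc3)nc2C)cc1` has not yet been measured in this assay. It differs from compound 3 in one place: 4-methoxyphenyl in place of 2-hydroxy-3-methoxyphenyl on a carbon with a double bond to nitrogen. Among the three measured compounds, varying the groups on this ring has moved nothing beyond the scatter, so the step of a 1.0-fold lower number from compound 3 to compound 4 (0.02 log units; within the scatter) is expected to be no change beyond the scatter. Compound 4 is accordingly estimated at 480 ug/mL, with a likely range from 300 ug/mL to 600 ug/mL. Whether the measurement bears that out remains to be seen.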

Compound 4, half-maximal inhibitory concentration: 500 ug/mL
Beside the measured number, compound 4's estimate is 1.0-fold (0.02 log units) below it; measured number inside the range.
By their numbers in this assay, from the lowest: compounds 1, 2, 3 and 4 (each within the scatter of the next).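

Among the compounds shown here, compound 4 supplies the first comparisons in which only one place differs, and all three point the same way in this assay. Putting 4-methoxyphenyl in place of 2-hydroxy-3-methoxyphenyl on a carbon with a double bond to nitrogen gives no change at the digits printed from compound 3 to compound 4 (within the scatter) and hydrogen in place of methoxy on an aromatic carbon gives a 1.1-fold higher number from compound 1 to compound 4 (0.05 log units; within the scatter) while 4-chlorophenyl in place of 3-chlorophenyl on an aromatic carbon gives no change at the digits printed from compound 2 to compound 4 (within the scatter) so none of these single changes separates its pair, whether it falls on the ring on the carbon with a double bond to nitrogen or on the chlorine-bearing ring. No measurement shown here offers an explanation for this level reading.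

On these data alone, all of these rings carry only methoxy, hydroxy or chloro groups, so it remains open whether an amine or a carboxylic acid on the ring, or a longer chain such as butoxy in place of methoxy, would produce a step beyond the scatter. Also open, as far as these compounds go, is whether replacing the chlorine with trifluoromethyl, or the whole chlorophenyl ring with a simple phenyl, would leave the reading level in this assay as well.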